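The source may report more compounds than this note shows. Statements on the series, on what has been measured and on what is new or still open speak of the compounds shown alone.

Among the measured compounds shown here, the three compounds measured so far share one core and differ in the group on the ring nitrogen and in the group attached to the carbonyl. Compound 1 `Nc1sc2c(c1C(=O)NNc1ccccc1)CCN(Cc1ccccc1)C2` gives 7800 nM in an in vitro assay on CHOk1 cells with adenosine receptor A1 (Homo sapiens) as the target; on this read-out lower numbers stand for an effect already at smaller amounts and higher numbers for an effect only at larger amounts of compound. Compound 2 `CN1CCc2c(sc(N)c2C(=O)NCc2ccccc2)C1` gives 12000 nM in this assay, and compound 3 `CN1CCc2c(sc(N)c2C(=O)NN)C1` gives 4400 nM. Compound 3 thus has the lowest of the three numbers, though its gap to compound 1 lies within the scatter, while the step of a 2.7-fold lower number from compound 2 to compound 3 (0.44 log units; beyond the scatter) lies beyond it.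

Compound 4 `CN1CCc2c(sc(N)c2C(=O)NNc2ccccc2)C1` is compound 3 with phenyl in place of hydrogen on an amine nitrogen. For the measured compounds named here, no measured step repeats this exact change. The step of a 2.7-fold lower number from compound 2 to compound 3 (0.44 log units; beyond the scatter) shows that taking a benzyl off the amide-type nitrogen lowered the number modestly, which hints that putting an aromatic ring back in this region may raise it; yet compound 1, which already carries the anilino group, shows a number within the scatter of compound 3. On balance a small rise is expected, and compound 4 is estimated at 6500 nM, with a range from 2500 nM to 16000 nM. The expected step is a 1.5-fold higher number from compound 3 to compound 4 (0.17 log units; within the scatter).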

Compound 4, half-maximal effective concentration: 11500 nM
Beside the measured number, compound 4's estimate is 1.8-fold (0.25 log units) below it; low and high end bracket the measured number.
By their numbers in this assay, from the lowest: compounds 3, 1, 4 and 2 (each within the scatter of the next, the first and the last beyond it).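

In this assay the step of a 2.6-fold higher number from compound 3 to compound 4 (0.42 log units; beyond the scatter) shows that an aromatic ring on this amine nitrogen, and not only the benzyl of compound 2, goes with a higher number than the bare amino end. The step of a 1.0-fold lower number from compound 2 to compound 4 (0.02 log units; within the scatter) puts anilino and benzyl on the amide-type nitrogen level with each other, and the step of a 1.5-fold higher number from compound 1 to compound 4 (0.17 log units; within the scatter) does the same for hydrogen or phenyl on the saturated chain carbon bound to the ring nitrogen, so among these compounds only compound 3 stands apart from compound 4 and compound 2. No measurement shown here offers an explanation for this result.

Going by these compounds, it remains open whether a methyl or a longer chain on this amine nitrogen would read like amino or like anilino. On these data alone, whether a carboxylic acid on the phenyl ring would shift the number is equally open.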